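A few compounds are considered here, and "the series" means these few. Any claim that something is new, unique, unknown or untested is made for them only; others in the source may bear on it.

Compound 1 `COc1ccc(Br)cc1-c1cc(CO)on1` was tested in a functional assay on BV-2 cells (Mus musculus) for inhibition, read by Griess assay, with a stated time of 24 h; a lower number here means a stronger inhibitor, a higher number a weaker inhibitor. In this assay compound 1 reaches only a limit, > 200000 nM. Compound 3 `C=CCc1ccc(OC)c(-c2cc(CO)on2)c1` carries the change (allyl in place of bromo on an aromatic carbon). In this assay compound 3 likewise reaches only a limit, > 200000 nM. The step that the two limits leave unreadable from compound 1 to compound 3 therefore cannot be sized, as both readings are limits rather than numbers. Compound 2 `COc1ccc(Br)cc1-c1cc(CN2CCN(C(=O)OC(C)(C)C)CC2)on1` has a different core from compound 1; the difference between the two cores is not broken down here. In this assay compound 2 also gives only a limit, > 200000 nM. Compound 4 `C=CCc1ccc(OC)c(-c2cc(CN3CCN(C(=O)OC(C)(C)C)CC3)on2)c1` has not yet been measured and differs from compound 2 by allyl in place of bromo on an aromatic carbon. This is the same kind of change as that from compound 1 to compound 3, though the surroundings differ: there the group sits meta to a group of 7 heavy atoms, here meta to a large group. All three measured values sit at the limit of > 200000 nM in this assay, at which 3 of the 3 values shown sit, which gives no usable size for the earlier step. The step from compound 2 to compound 4 is expected to be a number no higher from compound 2 to compound 4 (the limit leaves the size open), resting on compound 1 and compound 3 both sitting at the limit of > 200000 nM in this assay, at which 3 of the 3 values shown sit. Compound 4 is expected to give about 200000 nM in this assay, most probably again only as a limit, within 100000 nM to 1000000 nM.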

Compound 4, half-maximal inhibitory concentration: 76900 nM
The estimate for compound 4 lay 2.6-fold (0.42 log units) above the measured number; the measured number lies below the stated range.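

In this assay, allyl in place of bromo gives an at least 2.6-fold lower number from compound 2 to compound 4 (0.41 log units; beyond the scatter), so on the core of compound 2 this change does lower the number, and compound 4 is the only compound shown that gives a number rather than a limit. It does not show that the change carries over from one core to another: compound 1 and compound 3 both read only as limits, so the step between them cannot be read, and it neither supports nor contradicts the step on the other core. The comparison therefore rests on a single readable step, which is too little to establish a pattern across cores: the limit of > 200000 nM in this assay, at which 3 of the 4 values shown sit.

Still open, going by these compounds, is whether the double bond of the allyl group matters, which a saturated propyl chain in the same place on the core of compound 2 could test. Also open, on these data alone, is how a longer chain, an amine or a carboxylic acid in that place would read in this assay.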